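Hydrazone aryl variation on a shared core, cytotoxicity notes

The source may hold more compounds than are shown below. What is called first, only, known or untested is meant among the compounds shown, and "the series" means these compounds.

Measured compounds:
compound 1, `CN(C)CCn1cnnc1-c1cc(Oc2ccc(NC(=O)N/N=C/c3ccc(F)cc3F)cc2F)ccn1`, 810 nM in a functional assay on MKN-45 cells (Homo sapiens) for cytotoxicity, read by MTT assay, with a stated time of 72 h; a lower number here means a stronger inhibitor, a higher number a weaker inhibitor
compound 2, `CN(C)CCn1cnnc1-c1cc(Oc2ccc(NC(=O)N/N=C/c3cccc(Cl)c3Cl)cc2F)ccn1`, 51 nM in this assay
compound 3, `CN(C)CCn1cnnc1-c1cc(Oc2ccc(NC(=O)N/N=C/c3c(O)ccc4ccccc34)cc2F)ccn1`, 2020 nM in this assay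

Compound 3 gives the highest number of the three in this assay; its nearest neighbour is compound 1 at a 2.5-fold higher number from compound 1 to compound 3 (0.40 log units; beyond the scatter), and compound 2 is the furthest at a 40-fold higher number from compound 2 to compound 3 (1.60 log units; beyond the scatter). Compound 4, `CN(C)CCn1cnnc1-c1cc(Oc2ccc(NC(=O)N/N=C/c3ccc(O)c(F)c3)cc2F)ccn1`, has not yet been measured in this assay. It differs from compound 3 by 3-fluoro-4-hydroxyphenyl in place of 2-hydroxynaphthalen-1-yl on a carbon with a double bond to nitrogen.

Among the measured compounds shown here, two measured steps bear on this change, both in the opposite direction: swapping a phenyl-type aryl for the 2-hydroxynaphthalen-1-yl raised the number, by a 2.5-fold higher number from compound 1 to compound 3 (0.40 log units; beyond the scatter) and by a 40-fold higher number from compound 2 to compound 3 (1.60 log units; beyond the scatter). Reversing that swap, toward a single six-membered ring carrying a hydroxyl and a fluorine, should therefore lower the number beyond the scatter. How far depends on the substituents, and the spread between compound 1 and compound 2, a 16-fold lower number from compound 1 to compound 2 (1.20 log units; beyond the scatter), shows that this part is not settled by the data. Compound 4 is expected to land near compound 1, at 600 nM, within a range of 150 nM to 2500 nM. The estimate corresponds to an expected step of a 3.4-fold lower number from compound 3 to compound 4 (0.53 log units; beyond the scatter).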

Compound 4, half-maximal inhibitory concentration: 1970 nM
For compound 4 the middle estimate is 3.3-fold (0.52 log units) below the measured one; the range from low to high includes it.
By their numbers in this assay, from the lowest: compound 2; then compound 1; then compounds 4 and 3 (each within the scatter of the next).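

In this assay, 3-fluoro-4-hydroxyphenyl and 2-hydroxynaphthalen-1-yl on the carbon with a double bond to nitrogen cannot be told apart, a 1.0-fold lower number from compound 3 to compound 4 (0.01 log units; within the scatter), so one aromatic ring in place of two does not by itself lower the number at this position. The steps of a 2.4-fold higher number from compound 1 to compound 4 (0.39 log units; beyond the scatter) and a 39-fold higher number from compound 2 to compound 4 (1.59 log units; beyond the scatter) both lie beyond the scatter, so among these four compounds the two aryl groups carrying a hydroxyl sit at the high end of the series, the two carrying only halogens sit lower, and no compound goes against this. No measurement on hand accounts for this pattern, which remains a description of four compounds.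

The hydroxyl and the halogen pattern change together across these compounds, so their separate contributions to the number cannot be told apart, and the gap between the two halogen-only compounds remains unresolved. A methoxy group or an amine in place of the hydroxyl of 3-fluoro-4-hydroxyphenyl, with the fluorine kept, would show whether the hydroxyl itself goes with the higher numbers.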